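Thiophene series: tert-butyl amide to piperazinyl amide

This account rests on a few compounds, and the source may have more. Where it says the series, first, only, none or still open, it means among the compounds named here.

Compound 2 `CC(C)(C)NC(=O)c1c(N)sc(-c2ccc(Cl)cc2)c1-c1ccc(Cl)cc1` is the tert-butyl amide in a set of three related structures, the others being the butyl amide compound 1 `CCCCNC(=O)c1c(N)sc(-c2ccc(Cl)cc2)c1-c1ccc(Cl)cc1` and the cyclopropyl amide urea compound 3 `CCN(CC)CCNC(=O)Nc1sc(-c2ccc(Cl)cc2)c(-c2ccc(Cl)cc2)c1C(=O)NC1CC1`, for which no result was reported. In a functional assay on PC-3 cells (Homo sapiens) for inhibition, read by sulforhodamine B assay, with a stated time of 72 h (on this read-out lower numbers stand for stronger inhibition and higher numbers for weaker inhibition), compound 2 gives 15100 nM, the lowest of the two numbers available, and compound 1 gives 17800 nM. In this assay compound 3 gives "not determined" (no result reported). For the measured compounds named here, the one step joining the two measured compounds, a 1.2-fold lower number from compound 1 to compound 2 (0.07 log units; within the scatter), is the only measured step in the set and bears on nothing beyond the exchange of two alkyl groups on the amide nitrogen. Compound 4 `Nc1sc(-c2ccc(Cl)cc2)c(-c2ccc(Cl)cc2)c1C(=O)N1CCNCC1` differs from compound 2 as follows: piperazin-1-yl in place of (tert-butyl)amino on a carbonyl carbon. Going by the values given here, no measured step tests a change of this kind, so the expectation rests on the observation that the two measured amides sit close together. The step expected from compound 2 to compound 4 is a 1.0-fold lower number from compound 2 to compound 4 (0.00 log units; within the scatter), none beyond the scatter. Compound 4 is therefore estimated at 15000 nM, within a range from 5000 nM to 45000 nM.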

Compound 4, half-maximal inhibitory concentration: 2710 nM
Estimate against measurement, compound 4: 5.5-fold (0.74 log units) above; measured number outside the range, below it.
By their numbers in this assay, from the lowest: compound 4; then compounds 2 and 1 (each within the scatter of the next).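

Notes on the carbonyl position: in this assay this position responds to the group on the carbonyl carbon, with a 5.6-fold lower number from compound 2 to compound 4 (0.75 log units; beyond the scatter) and a 6.6-fold lower number from compound 1 to compound 4 (0.82 log units; beyond the scatter) both modest but beyond the scatter, whereas exchanging butyl for tert-butyl stayed within it. The two alkyl amides alone did not show this, and piperazin-1-yl is the only group shown that brings a six-membered non-aromatic ring to this place, with the hydrogen-bond donor count unchanged. No data shown here account for the lower number.

Still open, from the compounds shown here alone, is whether the ring or its second nitrogen carries the step, which a piperidin-1-yl or morpholin-4-yl group on the same carbonyl carbon would separate. A 4-methylpiperazin-1-yl group would likewise test whether the free ring amine matters.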